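The source may hold more compounds than are shown below. What is called first, only, known or untested is meant among the compounds shown, and "the series" means these compounds.

Compound 1, `CCOC(=O)C[C@H]1[C@@H](O[Si](C)(C)C(C)(C)C)[C@H](n2cnc3c(NC(=O)Nc4ccccc4)ncnc32)O[C@@H]1COC(=O)NC`, gives 2.42 nM in a functional assay on OVCAR-3 cells (Homo sapiens) for antiproliferative activity; a lower number here means a stronger inhibitor of growth, a higher number a weaker inhibitor of growth.
Compound 2, `CNC(=O)NC[C@H]1O[C@@H](n2cnc3c(NC(=O)Nc4ccccc4)ncnc32)[C@H](O[Si](C)(C)C(C)(C)C)[C@@H]1CC(=O)N(C)OC`, gives 7.11 nM in this assay.

Of these two measurements, compound 2 holds the higher number, and compound 1 the lower one; the gap between them lies beyond the usual scatter. Compound 1 and compound 2 differ in more than one place, so nothing further is said about what that gap shows. Among the measured compounds shown here, compound 3, `CCOC(=O)C[C@H]1[C@@H](O[Si](C)(C)C(C)(C)C)[C@H](n2cnc3c(NC(=O)Nc4ccccc4)ncnc32)O[C@@H]1CNC(=O)NC`, shares the rest of its structure with compound 2 and changes only one group on a carbonyl carbon whose other neighbour is a saturated chain carbon: ethoxy in place of methoxy(methyl)amino on a carbonyl carbon. The entering ethoxycarbonyl is the group that compound 1 also carries, and compound 1 gives 2.42 nM. On that ground compound 3 is expected to shift towards a lower number, and the change is expected to be modest, a 2.0-fold lower number from compound 2 to compound 3 (0.31 log units; beyond the scatter), at about the edge of the scatter. Compound 3 is therefore estimated at 3.5 nM, within a range from 1.5 nM to 8 nM.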

Compound 3, concentration for 50% growth inhibition: 4.59 nM
The estimate for compound 3 lay 1.3-fold (0.12 log units) below the measured number; the measured number falls inside the stated range.
By their numbers in this assay, from the lowest: compounds 1, 3 and 2 (each within the scatter of the next, the first and the last beyond it).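

In this assay, ethoxy in place of methoxy(methyl)amino on a carbonyl carbon gives a 1.5-fold lower number from compound 2 to compound 3 (0.19 log units; within the scatter), so at this position, on a saturated chain carbon, the two groups cannot be told apart. The other one-place change, (methylcarbamoyl)amino in place of (methylcarbamoyl)oxy on a saturated chain carbon bound to a saturated ring carbon, gives a 1.9-fold higher number from compound 1 to compound 3 (0.28 log units; within the scatter), so neither change taken alone reaches beyond the scatter. Nothing measured here accounts for these steps.

The compounds shown leave open whether a carboxylic acid, a primary amide or a longer alkoxy chain on this carbonyl carbon would move the number beyond the scatter. They also leave open how a plain amine would compare with (methylcarbamoyl)amino on the saturated chain carbon bound to a saturated ring carbon.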